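The compounds below may be only part of what the source reports. "The series", "measured", "known", "first", "only" and "open" are said of these compounds alone.

In an assay for displacement of a labelled ligand from melanin-concentrating hormone receptor 1 (Homo sapiens), read by fluorescence (on this read-out lower numbers stand for stronger inhibition and higher numbers for weaker inhibition), compound 1 `CC(=O)Nc1cccc(C2CCN(CCCn3c(-c4ccccc4)nc4ccccc43)CC2)c1` gives 2 nM, the lowest of the three numbers shown. Compound 2 `CC(=O)Nc1cccc(C2CCN(CCCn3c(-c4ccc(Br)cc4)nc4ccccc43)CC2)c1` gives 5 nM and compound 3 `CC(=O)Nc1cccc(C2CCN(CCCn3c(-c4ccc(Cl)c(Cl)c4)nc4ccccc43)CC2)c1` gives 24 nM. The steps are a 2.5-fold higher number from compound 1 to compound 2 (0.40 log units; beyond the scatter), a 12-fold higher number from compound 1 to compound 3 (1.08 log units; beyond the scatter) and a 4.8-fold higher number from compound 2 to compound 3 (0.68 log units; beyond the scatter). Compound 4 `CC(=O)Nc1cccc(C2CCN(CCCn3c(-c4ccc(F)cc4Cl)nc4ccccc43)CC2)c1` differs from compound 1 by 2-chloro-4-fluorophenyl in place of phenyl on an aromatic carbon. The two steps from compound 1, to compound 2 and to compound 3, bear on this change: a single bromo cost a modest amount, two chlorines a large amount. A weakening beyond the scatter is therefore expected in this assay for compound 4, likely between those two sizes, because of a 2.5-fold higher number from compound 1 to compound 2 (0.40 log units; beyond the scatter) and a 12-fold higher number from compound 1 to compound 3 (1.08 log units; beyond the scatter). The expected step is a 5.0-fold higher number from compound 1 to compound 4 (0.70 log units; beyond the scatter). Compound 4 is estimated at 10 nM, in the range 3 nM to 40 nM.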

Compound 4, half-maximal inhibitory concentration: 4 nM
Compound 4: middle estimate off by 2.5-fold (0.40 log units), on the high side; measured number inside the range.
By their numbers in this assay, from the lowest: compounds 1, 4 and 2 (each within the scatter of the next, the first and the last beyond it); then compound 3.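

In this assay, a phenyl carrying two halogens need not lose binding at this position: a 2.0-fold higher number from compound 1 to compound 4 (0.30 log units; within the scatter) stays level with the unsubstituted ring, and a 1.3-fold lower number from compound 2 to compound 4 (0.10 log units; within the scatter) shows no separation from the bromo compound either. Yet a 6.0-fold lower number from compound 3 to compound 4 (0.78 log units; beyond the scatter) sets 2-chloro-4-fluorophenyl clearly apart from 3,4-dichlorophenyl, so carrying two halogens does not by itself fix the number here. Nothing measured here explains that gap. Still open, on these data alone, is whether the chlorine or the fluorine alone would give the same number, and how a methoxy group or a pyridine ring in place of the phenyl would read.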